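This account rests on a few compounds, and the source may have more. Where it says the series, first, only, none or still open, it means among the compounds named here.

Compound 1 `COc1ccc(CO/N=C/c2c(C)nn(C)c2Oc2ccc(Cl)cc2)cc1` gives 13.9% in a functional assay on HepG2 cells (Homo sapiens) for antiproliferative activity, tested at 1 uM; on this read-out higher numbers stand for more inhibition at the one concentration tested (going by the name of the read-out) and lower numbers for less inhibition.
Compound 2 `CCOC(=O)c1ccc(CO/N=C/c2c(C)nn(C)c2Oc2ccc(Cl)cc2)cc1` gives 27.4% in this assay.
Compound 3 `CCOC(=O)c1ccc(CO/N=C/c2c(C)nn(-c3ccccc3)c2Oc2ccc(Cl)cc2)cc1` gives -31.8% in this assay.

Among these three numbers compound 2 stands highest. Its nearest neighbour is compound 1, reached by a number 13.5 percentage points higher from compound 1 to compound 2 (beyond the scatter), a change of ethoxycarbonyl in place of methoxy on an aromatic carbon. Its furthest neighbour is compound 3, reached by a number 59.2 percentage points lower from compound 2 to compound 3 (beyond the scatter), a change of phenyl in place of methyl on an aromatic nitrogen.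

Compound 4 `COC(=O)c1ccc(CO/N=C/c2c(C)nn(C)c2Oc2ccc(Cl)cc2)cc1` differs from compound 2 in one place: hydrogen in place of methyl on a saturated chain carbon bound to an oxygen next to a carbonyl group. Neither measured step covers this kind of change. The step from compound 1 to compound 2 exchanged a whole group on the aromatic carbon, and the step from compound 2 to compound 3 altered the aromatic nitrogen. Nothing measured here tests trimming the ethyl of the ester to a methyl. Among the compounds with values here, with so small a change and no step to lean on, the expected movement in this assay is none beyond the scatter, a number 4.4 percentage points lower from compound 2 to compound 4 (within the scatter). Compound 4 is therefore estimated at 23%, with a range from 8% to 38%.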

Compound 4, a percentage reported as inhibition, at one concentration (the size of the read-out at that concentration, not a potency): 20.3%
Beside the measured number, compound 4's estimate is 2.7 percentage points above it, and the stated range covers the measured number.
By their numbers in this assay, from the lowest: compound 3; then compounds 1, 4 and 2 (each within the scatter of the next, the first and the last beyond it).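

Trimming the ethyl of the ester to a methyl gives a number 7.1 percentage points lower from compound 2 to compound 4 (within the scatter) in this assay so this assay does not separate the two esters at this position. Methoxycarbonyl in place of methoxy on the aromatic carbon gives a number 6.4 percentage points higher from compound 1 to compound 4 (within the scatter) while ethoxycarbonyl there gave a number 13.5 percentage points higher from compound 1 to compound 2 (beyond the scatter) so the rise seen earlier does not carry over to both esters. No measured evidence accompanies these numbers to explain them.

Going by these compounds, it remains open how a longer chain such as propyl on the ester oxygen would read, or a carboxylic acid or an amide in place of the ester on the aromatic carbon. Also open, on these data alone, is whether the methyl ester, with phenyl in place of methyl on the aromatic nitrogen, would fall as compound 3 does.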